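Two pyridine amides on a benzyloxy-bearing core

A few compounds are considered here, and "the series" means these few. Any claim that something is new, unique, unknown or untested is made for them only; others in the source may bear on it.

Compound 1 `COc1ccc(C2=NN(C(=O)c3ccc(Cl)nc3)C(c3ccc(Cl)cc3)C2)cc1` and compound 2 `COc1ccc(C2=NN(C(=O)c3ccc(C)nc3Cl)C(c3ccc(Cl)cc3)C2)cc1` share a core, and in a functional assay on WM 266-4 cells (Homo sapiens) for antiproliferative activity, read by MTT assay, with a stated time of 24 h (a higher number here means a weaker inhibitor of growth, a lower number a stronger inhibitor of growth), compound 1 gives 1450 nM while compound 2 gives 1440 nM. They differ in one place, (2-chloro-6-methylpyridin-3-yl in place of 6-chloropyridin-3-yl on a carbonyl carbon), and that change made a step of a 1.0-fold lower number from compound 1 to compound 2 (0.00 log units; within the scatter). Compound 3 `COc1ccc(C2=NN(C(=O)c3ccc(Cl)nc3)C(c3ccc(OCc4ccccc4)cc3)C2)cc1` carries a different core; the difference is benzyloxy in place of chloro on an aromatic carbon, and in this assay compound 3 gives 10600 nM, a step of a 7.3-fold higher number from compound 1 to compound 3 (0.86 log units; beyond the scatter). Compound 4 `COc1ccc(C2=NN(C(=O)c3ccc(C)nc3Cl)C(c3ccc(OCc4ccccc4)cc3)C2)cc1` has not yet been measured. It differs from compound 3 in 2-chloro-6-methylpyridin-3-yl in place of 6-chloropyridin-3-yl on a carbonyl carbon, which is the same change as was made from compound 1 to compound 2, placed on a carbonyl carbon whose other neighbours are an amide-type nitrogen in a ring in both cases. Because the earlier step was a 1.0-fold lower number from compound 1 to compound 2 (0.00 log units; within the scatter), the expected step in this assay is no change at the digits printed from compound 3 to compound 4 (within the scatter), resting on that single pair alone. Compound 4 is therefore estimated to give 10600 nM, with the likely range running from 5000 nM to 22000 nM.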

Compound 4, concentration for 50% growth inhibition: 10500 nM
For compound 4 the middle estimate is 1.0-fold (0.00 log units) above the measured one, within the range that was stated.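

Replacing 6-chloropyridin-3-yl with 2-chloro-6-methylpyridin-3-yl on the benzyloxy-bearing core gives, in this assay, a 1.0-fold lower number from compound 3 to compound 4 (0.00 log units; within the scatter), and this matches what the same replacement did on the chloro-bearing core: the same change on two cores in this assay, a 1.0-fold lower number (0.00 log units; within the scatter) from compound 1 to compound 2 and a 1.0-fold lower number (0.00 log units; within the scatter) from compound 3 to compound 4, 1.0-fold (0.00 log units) apart, within the scatter of two such steps

Benzyloxy in place of chloro, now read with the other pyridine amide, gives a 7.3-fold higher number from compound 2 to compound 4 (0.86 log units; beyond the scatter), and this step also repeats: the same change on two cores in this assay, a 7.3-fold higher number (0.86 log units; beyond the scatter) from compound 1 to compound 3 and a 7.3-fold higher number (0.86 log units; beyond the scatter) from compound 2 to compound 4, 1.0-fold (0.00 log units) apart, within the scatter of two such steps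

Across these four compounds, each change therefore behaves the same whichever form the other part takes, but this does not show that it would carry over to a core beyond these, to other cells or to another exposure time, and it does not explain why either step has its size.

The compounds shown leave open what an amine or a carboxylic acid would do in place of chloro on that aromatic carbon, or a longer chain in place of benzyloxy. They also leave open whether an amine on the pyridine ring would produce a step beyond the scatter and, if so, whether that step would repeat on both cores.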